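The source may report more compounds than this note shows. Statements on the series, on what has been measured and on what is new or still open speak of the compounds shown alone.

Compound 1 `Cc1ccnc(/C(N)=N/NC(=S)N2CCSCC2)c1`: 33.8%
Compound 2 `Cc1cccc(/C(N)=N/NC(=S)N2CCCCC2)n1`: 27.1%
Compound 3 `Cc1ccnc(/C(N)=N/NC(=S)N2CCCCCC2)c1`: 36.3%

Of the compounds shown here, three have been tested in a functional assay on MCF7 cells (Homo sapiens) for cytotoxicity, read by MTT assay, with a stated time of 72 h, tested at 3 uM; on this read-out higher numbers stand for more inhibition of growth at the one concentration tested and lower numbers for less inhibition of growth. Compound 1 gives 33.8%, compound 2 gives 27.1%, and compound 3 gives 36.3%. Compound 2 shows the smallest of the three numbers, but the gap to compound 1 and the gap to compound 3 both lie within the usual scatter of this kind of measurement, so no order among the three can be read from these values, and all three sit in the same band of modest growth inhibition.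

Compound 4 `Cc1cccc(/C(N)=N/NC(=S)N2CCCC2)n1` has not yet been measured. It is built from compound 2 by one change: pyrrolidin-1-yl in place of piperidin-1-yl on a thiocarbonyl carbon. Among the compounds with values here, no measured pair differs in this way, so no directly comparable step exists. Given that the three measured compounds, which carry different saturated rings on the thiocarbonyl carbon, all fall within the scatter of one another, the change in ring size is expected to move the number little, in no clear direction, and not beyond the scatter. Compound 4 is therefore estimated to give about 28% in this assay, with a range from 16% to 40%. This estimate means an expected step of a number 0.9 percentage points higher from compound 2 to compound 4 (within the scatter) that stays within the scatter.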

Compound 4, percent growth inhibition at one concentration: 26.6%
For compound 4 the middle estimate is 1.4 percentage points above the measured one, within the range that was stated.
By their numbers in this assay, from the lowest: compounds 4, 2, 1 and 3 (each within the scatter of the next).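

Within the data shown here, the pair of compound 2 and compound 4 gives the first step in which only the group on the thiocarbonyl carbon differs, and in this assay pyrrolidin-1-yl in place of piperidin-1-yl gives a number 0.5 percentage points lower from compound 2 to compound 4 (within the scatter) on the shared core. Within this one pair, then, a five-membered non-aromatic ring and a six-membered non-aromatic ring on that carbon cannot be told apart by this read-out, and the measured change of ring size leaves the number inside the scatter. The earlier compounds could not show this, as they differ from one another in more than one place; no measurement is at hand that could explain the result.

Among these compounds, the single pair leaves open whether the same holds on the core of compound 1 and compound 3, which offers no such matched step here. Among the compounds shown here, it also leaves open how this read-out would respond on the core of compound 2 to a group of another kind on the thiocarbonyl carbon, such as an open-chain dimethylamino group or a 4-methylpiperazin-1-yl ring, whose second ring nitrogen has no counterpart in the piperidin-1-yl and pyrrolidin-1-yl groups compared here.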